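The source may hold more compounds than are shown below. What is called first, only, known or untested is meant among the compounds shown, and "the series" means these compounds.

Measured compounds:

- Compound 1, `Cc1ccc(/C=C/C(=O)Nc2ccc3nc(N4CCC(O)(C5CC5)CC4)nc(C)c3c2)cc1`: 344 nM
- Compound 2, `Cc1nc(NCCCNS(C)(=O)=O)nc2ccc(NC(=O)/C=C/c3ccc(OC(F)(F)F)cc3)cc12`: 54 nM
- Compound 3, `COCCC1(O)CCN(c2nc(C)c3cc(NC(=O)/C=C/c4ccc(Cl)cc4)ccc3n2)CC1`: 245 nM

These three compounds were tested in an assay on CHO-K1 cells for displacement of a labelled ligand from melanin-concentrating hormone receptor 1 (Homo sapiens), read by scintillation proximity assay, with a stated time of 2 h; on this read-out lower numbers stand for stronger inhibition and higher numbers for weaker inhibition. Compound 1 has the highest number of the three. Going by the values given here, its nearest neighbour is compound 3, whose number lies within the usual scatter of the one for compound 1, so no order can be claimed between those two. Compound 2 stands clearly apart, with a number beyond the scatter from that of compound 1; because compound 2 gives 54 nM, the lowest of the set, it is the only one shown to displace the labelled ligand more strongly than compound 1.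

Compound 4, `Cc1nc(N2CCC(O)(C3CC3)CC2)nc2ccc(NC(=O)/C=C/c3ccc(Cl)cc3Cl)cc12`, has not yet been measured. It differs from compound 1 in one place: 2,4-dichlorophenyl in place of 4-methylphenyl on a double-bonded chain carbon bound to a double-bonded chain carbon. Everything else in the molecule stays the same. Among the compounds with values here, no measured pair in this set shows the effect of exactly this change, so the expectation rests on the three numbers alone. A modest step toward a lower number in this assay is expected, roughly a 2.3-fold lower number from compound 1 to compound 4 (0.36 log units; beyond the scatter), though a step within the scatter cannot be ruled out. Compound 4 is therefore estimated at 150 nM, with a likely range from 50 nM to 450 nM.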

Compound 4, half-maximal inhibitory concentration: 620 nM
Estimate against measurement, compound 4: 4.1-fold (0.62 log units) below, and the stated range ends below it.
By their numbers in this assay, from the lowest: compound 2; then compounds 3, 1 and 4 (each within the scatter of the next, the first and the last beyond it).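

On the core of compound 1, replacing 4-methylphenyl with 2,4-dichlorophenyl on a double-bonded chain carbon bound to a double-bonded chain carbon gives, in this assay, a 1.8-fold higher number from compound 1 to compound 4 (0.26 log units; within the scatter). Going by these compounds alone, this is the first pair here that differs in only one place, so it gives the first direct reading of this position, and the two compounds cannot be put in order. Nothing available explains this result.

From the compounds shown here alone, it remains open whether a phenyl ring carrying an amine or a carboxylic acid at this place would give a step beyond the scatter. Also open, going by these compounds, is how the substituted phenyl groups of compound 2 and compound 3 would read on the core of compound 1, since each of those compounds differs from it in more than one place.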